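This account rests on a few compounds, and the source may have more. Where it says the series, first, only, none or still open, it means among the compounds named here.

Measured compounds:
- compound 1, `CN(C)CCCCCSC1=Nc2ccccc2C(CC(=O)NCc2ccccc2)N1c1ccc(-c2ccc(F)cc2)cc1`: 75.6%
- compound 2, `CN(C)CCCCCSC1=Nc2ccccc2C(CC(=O)NCc2ccccc2)N1c1ccc(-c2ccccc2)cc1`: 83.9%
- compound 3, `CN(C)CCCCCSC1=Nc2ccccc2C(CC(=O)NCc2ccccc2)N1c1ccccc1`: 51.8%

In an assay on cells for inhibition of Voltage-dependent T-type calcium channel subunit alpha-1H (Homo sapiens), read by patch clamp, tested at 10 uM (on this read-out lower numbers stand for less inhibition and higher numbers for more inhibition at the one concentration tested (going by the name of the read-out)), compound 1 stands second highest of the three. Its gap to compound 2, a number 8.3 percentage points higher from compound 1 to compound 2 (within the scatter), lies within the scatter, whereas the step to compound 3, a number 23.8 percentage points lower from compound 1 to compound 3 (beyond the scatter), lies beyond it. Compound 4, `CN(C)CCCCCSC1=Nc2ccccc2C(CC(=O)NCc2ccc(F)cc2)N1c1ccc(-c2ccc(F)cc2)cc1`, is not yet measured. It differs from compound 1 by fluoro in place of hydrogen on an aromatic carbon. Among the measured compounds shown here, no measured step touches the benzylamino end of the molecule. For the measured compounds named here, the only step that swaps fluoro for hydrogen, a number 8.3 percentage points higher from compound 1 to compound 2 (within the scatter), sat on the biaryl end and stayed within the scatter; the large steps of a number 32.1 percentage points lower from compound 2 to compound 3 (beyond the scatter) and a number 23.8 percentage points lower from compound 1 to compound 3 (beyond the scatter) concern loss of a whole ring, not fluorine. For compound 4 the expected step of a number 0.4 percentage points higher from compound 1 to compound 4 (within the scatter) is therefore small, within the scatter. Compound 4 is estimated at 76%, between 60% and 90%.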

Compound 4, a percentage reported as inhibition, at one concentration (the size of the read-out at that concentration, not a potency): 84.8%
For compound 4 the middle estimate is 8.8 percentage points below the measured one, and the stated range covers the measured number.
By their numbers in this assay, from the lowest: compound 3; then compounds 1, 2 and 4 (each within the scatter of the next).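

Among the compounds shown here, this is the first look at the benzylamino end of the molecule: putting fluoro on that benzyl ring gives a step, a number 9.2 percentage points higher from compound 1 to compound 4 (within the scatter), so 4-fluorobenzyl and benzyl cannot be told apart at this one concentration. The fluoro swap on the biaryl end, a number 8.3 percentage points higher from compound 1 to compound 2 (within the scatter), is also within the scatter, so in these compounds fluoro and hydrogen read alike at both ends.

As far as these compounds go, whether a larger group at this place, such as methoxy or a dimethylamino group, would shift the number stays open. Nothing shown offers a reason for this result.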